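Turning two ring stereocentres of compound 3

A few compounds are considered here, and "the series" means these few. Any claim that something is new, unique, unknown or untested is made for them only; others in the source may bear on it.

compound 1 `O=C(NCc1cc(Cl)ccc1-n1cnnn1)[C@@H]1C[C@@H]2C[C@@H]2N1C(=O)[C@H](O)CC1CC1` gives 1700 nM
compound 2 `CC(C)(C)OC[C@@H](O)C(=O)N1[C@H](C(=O)NCc2cc(Cl)ccc2-n2cnnn2)C[C@@H]2C[C@@H]21` gives 500 nM
compound 3 `CC(C)(C)C[C@@H](O)C(=O)N1[C@@H]2C[C@@H]2C[C@H]1C(=O)NCc1cc(Cl)ccc1-n1cnnn1` gives 520 nM

In a functional assay on a cell-free system (plasma, Homo sapiens), with a stated time of 3 min (a higher number here means a weaker inhibitor, a lower number a stronger inhibitor), compound 3 (520 nM) lies within the scatter of compound 2, and compound 1 has a clearly higher number than either. The next compound to be tested is compound 4 `CC(C)(C)C[C@@H](O)C(=O)N1[C@H](C(=O)NCc2cc(Cl)ccc2-n2cnnn2)C[C@@H]2C[C@@H]21`, and its relation to compound 3 is purely one of spatial arrangement: the two compounds have the same atoms and bonds and differ only in configuration as drawn: 2 of 4 stereo elements differ; a stereocentre at a saturated ring carbon is drawn R in compound 3 and S in compound 4; a stereocentre at a saturated ring carbon is drawn R in compound 3 and S in compound 4. Nothing is added or removed, so the question is only what this change of configuration does.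

The data give little direct help. Within the data shown here, the one measured step between close relatives is (a 3.4-fold lower number from compound 1 to compound 2 (0.53 log units; beyond the scatter)), a modest change. It concerns a chain group, tert-butoxy in place of cyclopropyl, and not the ring configuration, so its size cannot simply be carried over. Among the measured compounds shown here, no measured pair shows what turning these stereocentres does, and such a change could move the value in either direction. A lean towards a lower number is therefore a judgement with a wide margin, not a reading of the data. The expected change is (a 2.1-fold lower number from compound 3 to compound 4 (0.32 log units; beyond the scatter)) and remains only an estimate. Compound 4 is expected to give about 250 nM as a rough estimate. The estimated range for compound 4 runs from 40 nM to 1800 nM and reaches both sides of the starting value.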

Compound 4, half-maximal inhibitory concentration: 570 nM
Estimate against measurement, compound 4: 2.3-fold (0.36 log units) below, within the range that was stated.
By their numbers in this assay, from the lowest: compounds 2, 3 and 4 (each within the scatter of the next); then compound 1.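

In this assay, turning the two ring stereocentres gives a 1.1-fold higher number from compound 3 to compound 4 (0.04 log units; within the scatter), so for this pair the configuration at these ring carbons makes no difference that can be told apart from the scatter. Among these compounds, the chain group can now be compared on compound 4 as well: tert-butyl in place of tert-butoxy gives a 1.1-fold higher number from compound 2 to compound 4 (0.06 log units; within the scatter), whereas tert-butyl in place of cyclopropyl gives a 3.0-fold lower number from compound 1 to compound 4 (0.47 log units; beyond the scatter), so of these two chain changes only the one away from cyclopropyl lies beyond the scatter. The stereochemical reading is clean for one simple reason, which is that nothing else separates the pair: the fact that compounds 3 and 4 differ only in the configuration as drawn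

As far as these compounds go, the two stereocentres turn together here, so what each one does alone stays open, as does whether the same turn would matter with cyclopropyl or tert-butoxy on the chain. Also open, from the compounds shown here alone, is what an amine, a carboxylic acid or a longer chain would do in place of tert-butyl.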